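Furan to thiophene on a dihydropyrimidinone scaffold

The source may hold more compounds than are shown below. What is called first, only, known or untested is meant among the compounds shown, and "the series" means these compounds.

Measured compounds:
- compound 1 `CC1=C(C(=O)CC(C)C)C(c2cccs2)NC(=O)N1`: 43%
- compound 2 `CCNC(=O)C1=C(C)NC(=O)NC1c1ccco1`: 1%

In an assay on membranes from HEK293 cells for displacement of a labelled ligand from adenosine receptor A2b (Homo sapiens), read by scintillation counting, with a stated time of 30 min, tested at 1 uM (on this read-out higher numbers stand for more inhibition at the one concentration tested (going by the name of the read-out) and lower numbers for less inhibition), compound 1 gives 43%, while compound 2 gives 1%. Compound 2 therefore stands lowest of the two numbers, and its gap to compound 1 lies beyond the scatter. For the measured compounds named here, the two compounds differ in more than one place, so no single step between them can be read off.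

Compound 3 `CCNC(=O)C1=C(C)NC(=O)NC1c1cccs1` is not yet measured. It differs from compound 2 in one place only: thiophen-2-yl in place of furan-2-yl on a saturated ring carbon. Going by the values given here, no measured pair shows this exact change. Compound 1 also carries a thiophen-2-yl group, but its other differences from compound 2 leave the contribution of this ring unknown. The step of a number 7 percentage points higher from compound 2 to compound 3 (within the scatter) is expected to be small and upward, likely within the scatter. Compound 3 is estimated at 8%, in the range -5% to 25%.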

Compound 3, a percentage reported as inhibition, at one concentration (the size of the read-out at that concentration, not a potency): 1%
Estimate against measurement, compound 3: 7 percentage points above; the measured number falls inside the stated range.
By their numbers in this assay, from the lowest: compounds 2 and 3 (each within the scatter of the next); then compound 1.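

In this assay, thiophen-2-yl in place of furan-2-yl on the saturated ring carbon gives no change at the digits printed from compound 2 to compound 3 (within the scatter) with the ethylcarbamoyl group present, so this exchange alone does not move the number. The large step lies at the other place: ethylamino in place of isobutyl on the carbonyl carbon gives a number 42 percentage points lower from compound 1 to compound 3 (beyond the scatter), which shows that thiophen-2-yl alone does not carry the number seen for compound 1 and that the isobutyl group matters with this ring in place. No measurement here explains either step.

As far as these compounds go, whether furan-2-yl and thiophen-2-yl also match when isobutyl sits on the carbonyl carbon remains open. So does the effect of a phenyl ring on the saturated ring carbon, or of a longer alkyl chain or a morpholine on the carbonyl carbon.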